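A few compounds are considered here, and "the series" means these few. Any claim that something is new, unique, unknown or untested is made for them only; others in the source may bear on it.

Compounds measured so far in a functional assay on MDA-MB-231 cells (Homo sapiens) for antiproliferative activity, read by CCK-8 assay, with a stated time of 72 h; a lower number here means a stronger inhibitor, a higher number a weaker inhibitor:

- compound 1, `O=C(Nc1cccc(-c2oc3cc(-c4ccc(F)cc4)ccc3c(=O)c2O)c1)c1ccc(F)cc1F`: 11200 nM
- compound 2, `Cc1ccccc1C(=O)Nc1cccc(-c2oc3cc(-c4ccc(F)cc4)ccc3c(=O)c2O)c1`: 4910 nM
- compound 3, `O=C(Nc1cccc(-c2oc3cc(-c4ccc(F)cc4)ccc3c(=O)c2O)c1)c1cc(F)cc(F)c1`: 2440 nM

Compound 2 stands second highest of the three numbers. Its nearest neighbour is compound 3, and that pair lies within the scatter, so no order can be read between them. Compound 1 stands further off: a 2.3-fold lower number from compound 1 to compound 2 (0.36 log units; beyond the scatter). Compound 3 relative to compound 1 shows a 4.6-fold lower number from compound 1 to compound 3 (0.66 log units; beyond the scatter), and the pair of compound 2 and compound 3 shows a 2.0-fold lower number from compound 2 to compound 3 (0.30 log units; within the scatter).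

The next compound, compound 4, `O=C(Nc1cccc(-c2oc3cc(-c4ccc(F)cc4)ccc3c(=O)c2O)c1)c1ccc([N+](=O)[O-])cc1`, differs from compound 2 in one place: 4-nitrophenyl in place of 2-methylphenyl on a carbonyl carbon

The two measured steps that change the aryl group on the same carbonyl carbon, from compound 1 to compound 2 and from compound 2 to compound 3, are both modest, and one of them falls within the scatter. There is no measured compound carrying a nitro group, so the direction for compound 4 cannot be inferred from any shown step. The step from compound 2 to compound 4 is therefore expected to be small, close to the scatter, in this assay, and it is estimated as a 1.1-fold lower number from compound 2 to compound 4 (0.04 log units; within the scatter). Compound 4 is expected to give about 4500 nM, with a range from 1500 nM to 13000 nM.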

Compound 4, half-maximal inhibitory concentration: 14700 nM
Estimate against measurement, compound 4: 3.3-fold (0.51 log units) below; the whole stated range lies below it.
By their numbers in this assay, from the lowest: compounds 3 and 2 (each within the scatter of the next); then compounds 1 and 4 (each within the scatter of the next).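

In this assay, the 4-nitrophenyl group on the carbonyl carbon gives a 3.0-fold higher number from compound 2 to compound 4 (0.48 log units; beyond the scatter) and a 6.0-fold higher number from compound 3 to compound 4 (0.78 log units; beyond the scatter), so this position does not tolerate every aryl group equally, and a group carrying two hydrogen-bond acceptors brings no gain over the 2-methylphenyl or 3,5-difluorophenyl groups, which carry none. Against the 2,4-difluorophenyl group, the same change gives a 1.3-fold higher number from compound 1 to compound 4 (0.12 log units; within the scatter), so compound 1 and compound 4 cannot be ordered and together stand apart from compound 3, while the aryl groups shown give a similar upper end through two different substituents. Nothing available explains these differences.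

The compounds shown do not separate the kind of substituent from its place on the phenyl ring, since the nitro group appears in only one arrangement and no other single group shares that place. As far as these compounds go, how an amine, a carboxylic acid or a nitrile on this phenyl ring, or a longer chain in place of the ring, would read in this assay also stays open.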